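Glycosylated triazole series: arylidene swap to naphthyl

A few compounds are considered here, and "the series" means these few. Any claim that something is new, unique, unknown or untested is made for them only; others in the source may bear on it.

Of the compounds shown here, two have numbers so far. Compound 1 `COc1ccc(/C=C2\C(=O)N(Cc3cn([C@@H]4O[C@H](COC(C)=O)[C@@H](OC(C)=O)[C@H](OC(C)=O)[C@H]4OC(C)=O)nn3)c3ccccc32)cc1OC` gives 23300 nM in a functional assay on A549 cells (Homo sapiens) for cytotoxicity, read by sulforhodamine B assay, with a stated time of 48 h (on this read-out lower numbers stand for stronger inhibition and higher numbers for weaker inhibition), the highest of the two numbers in hand. Compound 2 `CC(=O)OC[C@H]1O[C@@H](n2cc(CN3C(=O)/C(=C/c4ccc(N(C)C)cc4)c4ccccc43)nn2)[C@H](OC(C)=O)[C@@H](OC(C)=O)[C@@H]1OC(C)=O` gives 19400 nM in this assay; the two values lie within the scatter of each other, so no order between compound 1 and compound 2 can be read from them.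

Compound 3 `CC(=O)OC[C@H]1O[C@@H](n2cc(CN3C(=O)/C(=C\c4ccc5ccccc5c4)c4ccccc43)nn2)[C@H](OC(C)=O)[C@@H](OC(C)=O)[C@@H]1OC(C)=O` has not been measured in this assay. It differs from compound 1 in one place: naphthalen-2-yl in place of 3,4-dimethoxyphenyl on a double-bonded chain carbon bound to a double-bonded ring carbon. Among the compounds with values here, no measured pair shows what such a change does, so no step size is known. Given that compound 1 and compound 2 sit close together despite their different arylidene groups, the expected step from compound 1 to compound 3 is a 1.3-fold lower number from compound 1 to compound 3 (0.11 log units; within the scatter), which is no more than the usual scatter. Compound 3 is therefore estimated at 18000 nM, with a range from 7000 nM to 45000 nM.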

Compound 3, half-maximal inhibitory concentration: 62200 nM
Beside the measured number, compound 3's estimate is 3.5-fold (0.54 log units) below it; measured number above the stated range.
By their numbers in this assay, from the lowest: compounds 2 and 1 (each within the scatter of the next); then compound 3.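

In this assay, within the data shown here, the group on a double-bonded chain carbon bound to a double-bonded ring carbon can shift the read-out: naphthalen-2-yl in place of 3,4-dimethoxyphenyl gives a 2.7-fold higher number from compound 1 to compound 3 (0.43 log units; beyond the scatter) and is the first step beyond the scatter. The heavy-atom count stays the same, while the 2 hydrogen-bond acceptors leave and a second six-membered aromatic ring enters, so this single step cannot separate those two differences. Nothing at hand accounts for the step.

The compounds shown leave open whether the loss of the two methoxy groups or the added ring carries the step. An unsubstituted phenyl or a 4-methoxyphenyl at this place would separate these two differences.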